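This account rests on a few compounds, and the source may have more. Where it says the series, first, only, none or still open, it means among the compounds named here.

Series notes, growth inhibition in a functional assay on MOLT-4F cells (Homo sapiens) for antiproliferative activity; a higher number here means a weaker inhibitor of growth, a lower number a stronger inhibitor of growth:
- compound 1 `COCCCCCCCCCCC/C=C1\CC(CO)(COC(=O)C(C)(C)C)OC1=O`: 2.38 ug/mL
- compound 2 `COC(=O)CCCCCCCCCCCCCC/C=C1\CC(CO)(COC(=O)C(C)(C)C)OC1=O`: > 10 ug/mL (a limit, not a number)
- compound 3 `CC(C)(C)C(=O)OCC1(CO)C/C(=C/CCCCCCCCCCCCCCC=O)C(=O)O1`: 2.02 ug/mL
- compound 4 `CC(=O)NCCCCCCCCCCCCCCC/C=C1\CC(CO)(COC(=O)C(C)(C)C)OC1=O`: not yet measured

Compound 2 stands at the limit of > 10 ug/mL in this assay, at which 1 of the 3 values shown sits. That entry is a limit of the assay, so its true distance from the other compounds is open. The next change is acetamidomethyl in place of methoxycarbonyl on a saturated chain carbon, ten or more bonds along the chain from a double-bonded chain carbon.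

Among the compounds with values here, only one measured step bears directly on this place: an at least 4.2-fold higher number from compound 1 to compound 2 (0.62 log units; beyond the scatter). It introduced the methoxycarbonyl-bearing group that now leaves, so removing that group may recover some activity. Within the data shown here, this is weak support, since the incoming acetamidomethyl has no measured precedent. Compound 3 also gives a number, 2.02 ug/mL, with a different group on the chain, so compound 2 is not a guide for every chain variant.

In this assay, a modest shift toward a lower number is expected, though a second limit remains quite possible. The estimated step is an at least 1.2-fold lower number from compound 2 to compound 4 (0.09 log units; that floor lies within the scatter). For compound 4 the expected value is 8 ug/mL, with an estimated range of 2.5 ug/mL to 20 ug/mL.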

Compound 4, concentration for 50% growth inhibition: 6.35 ug/mL
The estimate for compound 4 lay 1.3-fold (0.10 log units) above the measured number; measured number inside the range.
By their numbers in this assay, from the lowest: compounds 3 and 1 (each within the scatter of the next); then compound 4. At a limit, above all of these: compound 2.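

Compound 2 remains a limit, not a number, in this assay: the limit of > 10 ug/mL in this assay, at which 1 of the 4 values shown sits. Going by these compounds, at this saturated chain carbon, acetamidomethyl in place of methoxycarbonyl gives a measured value, with an at least 1.5-fold lower number from compound 2 to compound 4 (0.19 log units; that floor lies within the scatter), so the true size of this change remains open and only its floor can be stated. The comparison with compound 1 is firmer: a 2.7-fold higher number from compound 1 to compound 4 (0.43 log units; beyond the scatter), showing that the acetamido-ended chain does not return to the level of the methoxy-ended chain in this assay.

That last step replaces methoxy with 4-acetamidobutyl in a single change, so the compounds shown cannot separate the effect of the added chain length from that of the new chain end. Also open, on these data alone, is how a carboxylic acid or a primary amine at the same chain end would compare, and whether the acetamido group on a shorter chain, matching the chain of compound 1, would bring the value in this assay closer to that of compound 1.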